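This account rests on a few compounds, and the source may have more. Where it says the series, first, only, none or still open, it means among the compounds named here.

Measured compounds in an ADME assay on HEK293 cells (Homo sapiens) for cytotoxicity, read by MTT assay, with a stated time of 4 days; on this read-out higher numbers stand for weaker inhibition and lower numbers for stronger inhibition:

Compound 3 `O=c1[nH]c(-c2ccc(F)cc2)ccc1O` gives > 100000 nM, a limit of the assay.
Compound 1 `O=c1[nH]cc(-c2ccc(F)cc2)cc1O` gives > 100000 nM, also a limit of the assay.
Compound 2 `O=c1[nH]cc(-c2ccc(-c3nnn[nH]3)cc2)cc1O` gives 80000 nM.

Compound 3 stands at the limit of this assay, so only a bound is known for it; it shares that position with compound 1, as noted in the limit of > 100000 nM in this assay, at which 2 of the 3 values shown sit. Going by the values given here, the single computed step among the measured compounds, an at least 1.2-fold lower number from compound 1 to compound 2 (0.09 log units; that floor lies within the scatter), is the only guide, and its floor lies within the scatter of repeated measurements.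

Compound 4 `N#Cc1ccc(-c2ccc(O)c(=O)[nH]2)cc1` differs from compound 3 in one place: cyano in place of fluoro on an aromatic carbon. Among the compounds with values here, the one step on record, an at least 1.2-fold lower number from compound 1 to compound 2 (0.09 log units; that floor lies within the scatter), likewise replaced fluoro on an aromatic carbon with a nitrogen-containing group and produced nothing clearly beyond the scatter. Compound 4 is therefore expected to show no step beyond the scatter in this assay, which would leave it at or near the limit, and the estimated step is a number no higher from compound 3 to compound 4 (the limit leaves the size open). Compound 4 is estimated at 100000 nM, with a range of 50000 nM to 300000 nM, most likely reported again as a limit.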

Compound 4, half-maximal inhibitory concentration: >= 28000 nM
Compound 4 was reported as a limit (the forecaster's own chance of this, stated with the estimate: 70%); the middle value is on the limit's open side.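

In this assay no step can be read between compound 3 and compound 4, each being reported only as a limit. The compounds shown leave open whether cyano in place of fluoro on an aromatic carbon moves the number at all, and how far.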